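Swapping a benzothiophenylmethyl arm for a dichlorobenzoyl amide

This account rests on a few compounds, and the source may have more. Where it says the series, first, only, none or still open, it means among the compounds named here.

Measured compounds:
Compound 1, `COc1ccc2nccc(C3CN(C4CCCCN(Cc5cc6ccccc6[nH]5)C4)C(=O)O3)c2c1`: < 50200 nM
Compound 2, `O=C1OC(c2ccncc2)CN1C1CCN(Cc2cc3ccccc3[nH]2)CC1`: < 50200 nM
Compound 3, `COc1ccc2nccc(C3CN(C4CCN(Cc5cc6ccccc6s5)CC4)C(=O)O3)c2c1`: 794 nM

In an in vitro functional assay on RBL cells for antagonist activity at C-C chemokine receptor type 8 (Homo sapiens), read by FLIPR and calcium flux (a higher number here means a weaker inhibitor, a lower number a stronger inhibitor), compound 3 gives 794 nM. For compound 1 the result in this assay is only a limit, < 50200 nM, not a number. For compound 2 likewise the result is only a limit, < 50200 nM. So compound 3 carries the one real number in the set, and the other two entries sit at the limit of < 50200 nM in this assay, at which 2 of the 3 values shown sit, which allows no comparison of size between them and compound 3 beyond saying that compound 3 is inside the measurable range.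

Compound 4, `COc1ccc2nccc(C3CN(C4CCN(C(=O)c5ccc(Cl)c(Cl)c5)CC4)C(=O)O3)c2c1`, is not yet measured. It differs from compound 3 in one place: (3,4-dichlorophenyl)carbonyl in place of (1-benzothiophen-2-yl)methyl on an amine nitrogen in a ring. No step between two measured compounds is available to gauge this kind of swap, since the pairs shown here differ in more than one place or end at a limit. The change is therefore judged from compound 3 alone. Compound 4 is expected to be weaker than compound 3, with a step of a 5.0-fold higher number from compound 3 to compound 4 (0.70 log units; beyond the scatter) in this assay, and its estimated value is 4000 nM, most likely between 600 nM and 25000 nM.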

Compound 4, half-maximal inhibitory concentration: 6310 nM
The estimate for compound 4 lay 1.6-fold (0.20 log units) below the measured number, and the stated range covers the measured number.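

In this assay, for the compounds shown here, the (3,4-dichlorophenyl)carbonyl group in place of (1-benzothiophen-2-yl)methyl gives a 7.9-fold higher number from compound 3 to compound 4 (0.90 log units; beyond the scatter) on the amine nitrogen in a ring, and this is the only step in the set that can be read as a number. It shows that the group on this nitrogen matters to the read-out, and that an amide carrying one six-membered aromatic ring of carbon only still gives a measured value and not a limit. The compounds shown offer no reason for the size of this step.

The swap changes the carbonyl and the aromatic arm at once, so these compounds cannot separate the two. From the compounds shown here alone, how a (3,4-dichlorophenyl)methyl arm, which keeps the dichlorophenyl ring without the carbonyl, or a (1-benzothiophen-2-yl)carbonyl arm would read remains open.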